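Benzyl Substituent Effects on Dopamine Beta-Hydroxylase Inhibition

This account rests on a few compounds, and the source may have more. Where it says the series, first, only, none or still open, it means among the compounds named here.

Measured so far:
Compound 1, `O=C(O)c1nccn1Cc1ccccc1`: 57000 nM
Compound 2, `NCc1nccn1Cc1ccc(O)cc1`: 165000 nM
Compound 3, `Sc1nncn1Cc1ccccc1`: 24000 nM

Of the compounds shown here, three have been tested in an assay on isolated protein for inhibition of Dopamine beta-hydroxylase (Bos taurus); on this read-out higher numbers stand for weaker inhibition and lower numbers for stronger inhibition. Compound 1 gives 57000 nM in this assay, compound 2 gives 165000 nM, and compound 3 gives 24000 nM. On these numbers compound 3 stands lowest, so it is the strongest inhibitor of the three; the gap to compound 1 and the larger gap to compound 2 both lie beyond the usual scatter of repeated measurements.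

The next compound, compound 4, `Fc1cccc(Cn2cnnc2S)c1`, differs from compound 3 in a single place: fluoro in place of hydrogen on an aromatic carbon, on an aromatic carbon of a six-membered aromatic ring of carbon only, meta to a group of 7 heavy atoms. Within the data shown here, no pair of measured compounds shows this kind of change, so there is no measured step to lean on, and the shared core of compound 3 is kept unchanged.

A single fluoro in place of hydrogen is a small alteration. The expectation is a modest step in this assay, at most slightly toward stronger inhibition, and possibly none beyond the scatter; the expected step is a 1.6-fold lower number from compound 3 to compound 4 (0.20 log units; within the scatter). Compound 4 is estimated at 15000 nM, within a range from 5000 nM to 50000 nM.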

Compound 4, half-maximal inhibitory concentration: 1900 nM
Compound 4: middle estimate off by 7.9-fold (0.90 log units), on the high side; measured number outside the range, below it.
By their numbers in this assay, from the lowest: compound 4; then compound 3; then compound 1; then compound 2.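

In this assay the aromatic carbon meta to a group of 7 heavy atoms proves to be a sensitive place, since fluoro in place of hydrogen there gives a 13-fold lower number from compound 3 to compound 4 (1.10 log units; beyond the scatter) and that large step comes from just one entering heavy atom. Among these compounds, none of the earlier compounds formed a pair differing in one place, so this is the first measured step, and for now it rests on this single pair. Among the compounds shown here, nothing available accounts for why one fluoro moves the number so far.

The compounds shown leave open whether this step belongs to fluoro itself or would also appear with a chloro, a methyl or a methoxy group at the same carbon. They also leave open whether the same swap would give a step of similar size on the core of compound 1, which carries a carboxylic acid where compound 4 has its own, different shared core.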